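Shrinking the cyclohexyl ring on a triazolopyrimidine amide

The source may report more compounds than this note shows. Statements on the series, on what has been measured and on what is new or still open speak of the compounds shown alone.

Measured compounds:
compound 1, `O=C(Nc1nc(-c2ccccc2)nc2c1nnn2Cc1ccccc1)C1CCCCC1`, 12 nM
compound 2, `COc1ccc(Cl)cc1C(=O)Nc1nc(-c2ccccc2)nc2c1nnn2Cc1ccccc1`, 7150 nM
compound 3, `O=C(Nc1nc(-c2ccccc2)nc2c1nnn2Cc1ccccc1)c1ccc(Cl)cc1`, 108 nM

All three share one core and differ only in the group attached to the carbonyl carbon of the amide. In an assay (strain Wistar) for displacement of a labelled ligand from adenosine receptor A1 (Rattus norvegicus), read by scintillation counting (on this read-out lower numbers stand for stronger inhibition and higher numbers for weaker inhibition), compound 1 gives the lowest number of the three: compound 3 lies a 9.0-fold higher number from compound 1 to compound 3 (0.95 log units; beyond the scatter) away and compound 2 a 600-fold higher number from compound 1 to compound 2 (2.78 log units; beyond the scatter) away, both beyond the scatter, so compound 1 is the strongest binder among the measured set.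

Compound 4, `O=C(Nc1nc(-c2ccccc2)nc2c1nnn2Cc1ccccc1)C1CC1`, has not yet been measured. It differs from compound 1 by cyclopropyl in place of cyclohexyl on a carbonyl carbon.

The measured steps all start from the cyclohexyl of compound 1 and replace it with a substituted phenyl: a 600-fold higher number from compound 1 to compound 2 (2.78 log units; beyond the scatter) and a 9.0-fold higher number from compound 1 to compound 3 (0.95 log units; beyond the scatter). Both weaken binding, one modestly, one greatly. Neither step replaces the cyclohexyl with a smaller saturated ring, so the data offer no direct guide for compound 4. Since every departure from cyclohexyl measured so far raised the number, a modest rise is expected for compound 4 rather than an improvement, with wide uncertainty: an estimated step of a 3.3-fold higher number from compound 1 to compound 4 (0.52 log units; beyond the scatter).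

For compound 4 the expected value in this assay is 40 nM, estimated to fall between 8 nM and 200 nM.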

Compound 4, inhibition constant: 7.5 nM
Compound 4: middle estimate off by 5.3-fold (0.73 log units), on the high side, and the stated range ends above it.
By their numbers in this assay, from the lowest: compounds 4 and 1 (each within the scatter of the next); then compound 3; then compound 2.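

In this assay the swap of cyclohexyl for cyclopropyl on the carbonyl carbon gives a difference that stays within the usual scatter (a 1.6-fold lower number from compound 1 to compound 4 (0.20 log units; within the scatter)), so the two compounds cannot be told apart. At this position, then, a saturated carbon ring of 3 heavy atoms serves as well as one of 6 heavy atoms, and leaving cyclohexyl does not by itself cost binding. The weak binding seen earlier instead goes with the substituted phenyl groups, as cyclopropyl gives a large step from the 4-chlorophenyl amide (a 14-fold lower number from compound 3 to compound 4 (1.16 log units; beyond the scatter)) and a far larger one from the 5-chloro-2-methoxyphenyl amide (a 950-fold lower number from compound 2 to compound 4 (2.98 log units; beyond the scatter)).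

The compounds shown leave open how an open chain such as isopropyl or tert-butyl would compare with these two rings, and whether a plain phenyl with no chlorine or methoxy would sit nearer the saturated rings or the substituted phenyl groups. Nothing available here explains why these groups rank as they do.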